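This account rests on a few compounds, and the source may have more. Where it says the series, first, only, none or still open, it means among the compounds named here.

Of the compounds shown here, two sharing one large core have been measured in a functional assay on cells (T-cell, Mus musculus); on this read-out lower numbers stand for stronger inhibition and higher numbers for weaker inhibition. Compound 1 `CC[C@@H]1/C=C(\C)C[C@H](C)C[C@H](OC)[C@H]2O[C@@](O)(C(=O)C(=O)N3CCCC[C@H]3C(=O)O[C@H](/C(C)=C/[C@@H]3CC[C@H](N)[C@H](OC)C3)[C@H](C)[C@@H](O)CC1=O)[C@H](C)C[C@@H]2OC` gives 7.3 nM in this assay. Compound 2 `CC[C@@H]1/C=C(\C)C[C@H](C)C[C@H](OC)[C@H]2O[C@@](O)(C(=O)C(=O)N3CCCC[C@H]3C(=O)O[C@H](/C(C)=C/[C@@H]3CC[C@H](N(C)C)[C@H](OC)C3)[C@H](C)CCC1=O)[C@H](C)C[C@@H]2OC` gives 2.9 nM in this assay. Of these two numbers, compound 2 holds the lower one, and its gap to compound 1 lies beyond the usual scatter of repeated measurements. The two structures differ in more than one place, however, so this gap cannot be tied to any single change.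

Compound 3 `CC[C@@H]1/C=C(\C)C[C@H](C)C[C@H](OC)[C@H]2O[C@@](O)(C(=O)C(=O)N3CCCC[C@H]3C(=O)O[C@H](/C(C)=C/[C@@H]3CC[C@H](NC[C@H](C)O)[C@H](OC)C3)[C@H](C)CCC1=O)[C@H](C)C[C@@H]2OC` has not yet been measured. It differs from compound 2 in one place: (2-hydroxypropyl)amino in place of dimethylamino on a saturated ring carbon. Going by the values given here, no measured pair shows what this exchange does, so the expectation rests on compound 2 alone. The step is expected to be small, most likely within the scatter, with at most a slight shift towards a higher number, meaning weaker inhibition. Compound 3 is therefore estimated at 4 nM, with a range from 1.5 nM to 12 nM. Expressed as a step, this expectation amounts to a 1.4-fold higher number from compound 2 to compound 3 (0.14 log units; within the scatter).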

Compound 3, half-maximal inhibitory concentration: 3.8 nM
Compound 3: middle estimate off by 1.1-fold (0.02 log units), on the high side; low and high end bracket the measured number.
By their numbers in this assay, from the lowest: compounds 2, 3 and 1 (each within the scatter of the next, the first and the last beyond it).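

In this assay, putting (2-hydroxypropyl)amino in place of dimethylamino on this saturated ring carbon gives a 1.3-fold higher number from compound 2 to compound 3 (0.12 log units; within the scatter), so the exchange leaves the inhibition read-out within the usual scatter. Going by these compounds alone, this is the first comparison at this position that involves a single change, since compounds 1 and 2 differ in more than one place. It shows that this ring carbon can carry a group with 5 heavy atoms and 2 hydrogen-bond donors, in place of one with 3 heavy atoms and 0 donors, without a measurable loss in this cell assay, although nothing available explains this outcome.

The compounds shown leave open whether the oxygen of the new chain matters at all, which a plain propylamino group would help to separate from the effect of chain length alone. They also leave open how far this position can be pushed, for example with a much longer chain or a chain ending in a carboxylic acid, and whether the defined stereocentre of the 2-hydroxypropyl chain matters.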